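The source may report more compounds than this note shows. Statements on the series, on what has been measured and on what is new or still open speak of the compounds shown alone.

Measured compounds:
Compound 1, `NC(=O)CCCn1c(Cn2c(=O)n(C3CC3)c3ccncc32)cc2cc(Cl)ccc21`, in an ADME assay on HeLa cells (Homo sapiens) for cytotoxicity, read by ATP content, with a stated time of 3 days (on this read-out lower numbers stand for higher toxicity in this test and higher numbers for lower toxicity in this test), gives > 50000 nM, a limit of the assay and not a number.
Compound 2, `O=c1n(Cc2cc3cc(Cl)ccc3n2CCCCF)c2cnccc2n1C1CC1`, in this assay gives > 50000 nM, again a limit.
Compound 3, `CC(C)(O)CCCn1c(Cn2c(=O)n(C3CC3)c3ccncc32)cc2cc(Cl)ccc21`, in this assay gives > 50000 nM, also a limit.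

Among the compounds with values here, compound 3 thus stands at the limit of the test, as do the two other compounds measured so far (the limit of > 50000 nM in this assay, at which 3 of the 3 values shown sit); none of the three can be told apart from another on these numbers. The compound still to be measured, compound 4, `N=C(CCCn1c(Cn2c(=O)n(C3CC3)c3ccncc32)cc2cc(Cl)ccc21)NO`, differs from compound 3 by a group of 4 heavy atoms (1 carbon, 2 nitrogen, 1 oxygen; no ring) in place of a group of 4 heavy atoms (3 carbon, 1 oxygen; no ring), on a saturated chain carbon, three bonds along the chain from an aromatic nitrogen. The measured steps that touch the same position are a step that the two limits leave unreadable from compound 1 to compound 3 and a step that the two limits leave unreadable from compound 2 to compound 3; both run between two limits and show no size. The step that the two limits leave unreadable from compound 1 to compound 2 is unreadable in the same way. No direction and no size can be taken from them, so no change beyond the scatter is expected; the step of a number no higher from compound 3 to compound 4 (the limit leaves the size open) is expected to be nothing readable. Compound 4 is therefore expected to give about 50000 nM, in a range from 20000 nM to 200000 nM.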

Compound 4, half-maximal cytotoxic concentration: > 50000 nM
Compound 4: a limit, no number; the forecaster's own chance of this, stated with the estimate: 85%; the middle value lies on the limit itself.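

No step between compound 1, compound 2, compound 3 and compound 4 can be read in this assay, because each gives a limit and not a number: the limit of > 50000 nM in this assay, at which 4 of the 4 values shown sit.

The compounds shown leave open whether exchanging these groups on the chain changes the toxicity at all.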